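Two compounds at the limit of the assay

The source may report more compounds than this note shows. Statements on the series, on what has been measured and on what is new or still open speak of the compounds shown alone.

In an ADME assay on Huh7.5.1 cells (Homo sapiens) for cytotoxicity, read by WST assay, with a stated time of 48 h (a higher number here means that more compound is tolerated, a lower number that less compound is tolerated), compound 1 (`Cc1c(-c2ccc(Oc3ccc(SC(F)(F)F)cc3)c(F)c2)[nH]c2cccc(F)c2c1=O`) gives > 10000 nM as a limit of the assay. Compound 2 (`Cc1c(-c2ccc(Oc3ccc(N4CCCC4)cc3)c(F)c2)[nH]c2cccc(F)c2c1=O`) gives > 10000 nM and this too is a limit. Both values sit at that one limit (the limit of > 10000 nM in this assay, at which 2 of the 2 values shown sit) so the step that the two limits leave unreadable from compound 1 to compound 2 has no readable size and shows no direction. Compound 3 (`CCCN(CC)c1ccc(Oc2ccc(-c3[nH]c4cccc(F)c4c(=O)c3C)cc2F)cc1`) carries ethyl(propyl)amino in place of pyrrolidin-1-yl on an aromatic carbon. No change beyond the scatter is therefore expected in this assay for this swap. The expected step is a step that the limit leaves unreadable from compound 2 to compound 3 on this estimate. For compound 3 the estimated value is 12000 nM (expected range 6000 nM to 30000 nM).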

Compound 3, half-maximal cytotoxic concentration: > 10000 nM
Compound 3 gave a limit, no number; the forecaster's own chance of this, stated with the estimate: 85%; the middle value lies beyond the limit too.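

Among these compounds, compound 3 also gives a limit and not a number, so no step among compound 1, compound 2 and compound 3 can be read: the limit of > 10000 nM in this assay, at which 3 of the 3 values shown sit. On these data alone, whether these group swaps change the outcome in this assay stays open.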